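A few compounds are considered here, and "the series" means these few. Any claim that something is new, unique, unknown or untested is made for them only; others in the source may bear on it.

In an ADME assay on BHK-21 cells (Mesocricetus auratus) for cytotoxicity, read by MTT assay, with a stated time of 72 h (a lower number here means that less compound is tolerated, a higher number that more compound is tolerated), compound 2 (`Cc1ccc(NCc2cn(-c3ccccc3)nc2-c2ccc(C)cc2)cc1`) reads > 100000 nM which is a limit and not a number. Compound 3 (`Cc1ccc(NCc2cn(-c3ccccc3)nc2-c2ccc(Br)cc2)cc1`) reads > 100000 nM which is also a limit. Compound 1 (`Cc1ccc(NCc2cn(-c3ccccc3)nc2-c2ccc(C(F)(F)F)cc2)cc1`) gives 88000 nM as a number. Compound 4 (`Cc1ccc(-c2nn(-c3ccccc3)cc2CNc2ccc(Cl)cc2)cc1`) differs from compound 2 by chloro in place of methyl on an aromatic carbon at the group that goes from (4-methylphenyl)amino to (4-chlorophenyl)amino. The measured swaps lie elsewhere in the molecule, so they bear on this change only loosely. Methyl in place of trifluoromethyl gave an at least 1.1-fold higher number from compound 1 to compound 2 (0.05 log units; that floor lies within the scatter) and bromo in place of trifluoromethyl gave an at least 1.1-fold higher number from compound 1 to compound 3 (0.05 log units; that floor lies within the scatter) on that other group. Compound 3 shows a step that the two limits leave unreadable from compound 2 to compound 3 for bromo in place of methyl, the closest swap. In this assay no step beyond the scatter is expected and the estimate is an at least 1.0-fold lower number from compound 2 to compound 4 (0.02 log units; that floor lies within the scatter) for chloro in place of methyl. Compound 4 is estimated at 95000 nM with an expected range from 50000 nM as the lower end to 150000 nM as the upper end.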

Compound 4, half-maximal cytotoxic concentration: > 100000 nM
Compound 4 was reported as a limit (the forecaster's own chance of this, stated with the estimate: 65%); middle value at least 1.0-fold (0.02 log units) from the limit.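

In this assay compound 4 gives > 100000 nM, a limit and not a number. Among these compounds, compound 2 also stands at a limit, and no step to compound 4 can be read. The compounds shown leave open how chloro and methyl compare at this group, because the readings stop at a shared limit: the limit of > 100000 nM in this assay, at which 3 of the 4 values shown sit.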